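A few compounds are considered here, and "the series" means these few. Any claim that something is new, unique, unknown or untested is made for them only; others in the source may bear on it.

Measured so far in a functional assay on HeLa cells (Homo sapiens) for antiproliferative activity, read by sulforhodamine B assay, with a stated time of 48 h; on this read-out higher numbers stand for weaker inhibition and lower numbers for stronger inhibition:
compound 1, `NS(=O)(=O)c1ccc(N/C(S)=N\c2ccnc3cc(C(F)(F)F)ccc23)cc1`: 36600 nM
compound 2, `N=C(N)NS(=O)(=O)c1ccc(N/C(S)=N\c2ccnc3cc(C(F)(F)F)ccc23)cc1`: 23900 nM
compound 3, `O=S(=O)(Nc1nccs1)c1ccc(N/C(S)=N\c2ccnc3cc(C(F)(F)F)ccc23)cc1`: 95200 nM

Compound 3 stands at the highest number of the three. The two steps leading to it, a 2.6-fold higher number from compound 1 to compound 3 (0.42 log units; beyond the scatter) and a 4.0-fold higher number from compound 2 to compound 3 (0.60 log units; beyond the scatter), are both beyond the scatter and modest in size; each changes only what sits on the sulfonamide nitrogen, and each reads as weaker inhibition once the 1,3-thiazol-2-yl group is in place.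

Compound 4 is `O=S(=O)(Nc1ccccn1)c1ccc(N/C(S)=N\c2ccnc3cc(C(F)(F)F)ccc23)cc1`. Its change from compound 3: pyridin-2-yl in place of 1,3-thiazol-2-yl on a sulfonamide nitrogen. Among the compounds with values here, no measured pair compares two aromatic rings on the sulfonamide nitrogen, so a 2.6-fold higher number from compound 1 to compound 3 (0.42 log units; beyond the scatter) and a 4.0-fold higher number from compound 2 to compound 3 (0.60 log units; beyond the scatter) bear on this step only indirectly: they show the number moving modestly when an aromatic ring replaced hydrogen, or the group carried by compound 2, at that position. Swapping one aromatic ring for another is expected to move the number less than that. The expected step is therefore a 1.3-fold lower number from compound 3 to compound 4 (0.10 log units; within the scatter), at or within the scatter, with no firm direction. Compound 4 is estimated at 75000 nM, with a range of 35000 nM to 160000 nM.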

Compound 4, half-maximal inhibitory concentration: 68800 nM
Beside the measured number, compound 4's estimate is 1.1-fold (0.04 log units) above it; low and high end bracket the measured number.
By their numbers in this assay, from the lowest: compounds 2, 1, 4 and 3 (each within the scatter of the next, the first and the last beyond it).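

In this assay, one aromatic ring in place of another on the sulfonamide nitrogen gives a first direct comparison (a 1.4-fold lower number from compound 3 to compound 4 (0.14 log units; within the scatter)), and pyridin-2-yl and 1,3-thiazol-2-yl are not separated by it. Pyridin-2-yl in place of hydrogen stays within the scatter (a 1.9-fold higher number from compound 1 to compound 4 (0.27 log units; within the scatter)), unlike 1,3-thiazol-2-yl (a 2.6-fold higher number from compound 1 to compound 3 (0.42 log units; beyond the scatter)), so a ring on this nitrogen does not always move the number beyond the scatter, while the gap to the group on compound 2 persists (a 2.9-fold higher number from compound 2 to compound 4 (0.46 log units; beyond the scatter)). No evidence is at hand that would explain these steps.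

Open, from the compounds shown here alone, is how phenyl, methyl or acetyl on the sulfonamide nitrogen would compare with these rings. Also open, going by these compounds, is whether these steps would hold with chlorine or methoxy in place of the trifluoromethyl group on the shared core.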